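Ring configuration in a phenylcyclohexyl ethylamine pair

A few compounds are considered here, and "the series" means these few. Any claim that something is new, unique, unknown or untested is made for them only; others in the source may bear on it.

Measured compounds:
compound 1 `c1ccc(CNCC[C@@H]2CCC[C@@H](c3ccccc3)C2)cc1` gives 1.8 nM; 2.4 nM (2 entries)
compound 2 `c1ccc(CNCC[C@H]2CCC[C@H](c3ccccc3)C2)cc1` gives 1.4 nM

In an assay on membranes from brain for displacement of a labelled ligand from Sigma non-opioid intracellular receptor 1 (Cavia porcellus), read by scintillation counting, with a stated time of 120 min (on this read-out higher numbers stand for weaker inhibition and lower numbers for stronger inhibition), compound 1 gives 1.8 nM; 2.4 nM (2 entries) and compound 2 gives 1.4 nM. The repeat entries of compound 1 the several entries of compound 1 in this assay, 1.8 nM; 2.4 nM (2 entries) sit close together, and the two compounds differ only in the configuration as drawn (the fact that compounds 1 and 2 differ only in the configuration as drawn); their values lie within the scatter of each other, so no order can be read between them. Compound 2 stands on the only number shown for it, with one further entry that carries no single number.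

Compound 3 `c1ccc(CNCC[C@H]2CCC[C@@H](c3ccccc3)C2)cc1` is the next step. It differs from compound 2 in this way: the two compounds have the same atoms and bonds and differ only in configuration as drawn: 1 of 2 stereo elements differ; a stereocentre at a saturated ring carbon is drawn S in compound 2 and R in compound 3. For the measured compounds named here, no step between measured compounds exists for this kind of change, as both measured compounds share the same relative arrangement of the two stereocentres. Given that the two drawn configurations measured so far both bind tightly, the change of one ring stereocentre is expected to cost little, perhaps a modest loss, but not more than a small step.

Compound 3 is expected to give 3.5 nM, with a range from 0.9 nM to 15 nM. The expected step is a 2.5-fold higher number from compound 2 to compound 3 (0.40 log units; beyond the scatter).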

Compound 3, inhibition constant: 1.3 nM
The estimate for compound 3 lay 2.7-fold (0.43 log units) above the measured number; the measured number falls inside the stated range.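

For the compounds shown here, compound 3 is the first compound here with the two ring stereocentres in the other relative arrangement, as compounds 1 and 2 share one arrangement. In this assay, redrawing one saturated ring carbon from S to R gives a 1.1-fold lower number from compound 2 to compound 3 (0.03 log units; within the scatter), so no cost can be read for this change at this position, and the relative arrangement does not separate these two compounds on this read-out. The comparison involves no other structural change, which makes it a direct reading of this one stereocentre: the fact that compounds 2 and 3 differ only in the configuration as drawn

With all values this close, the compounds shown cannot tell whether configuration at this carbon would matter in a compound with a different amine substituent, such as a phenethyl group in place of the benzyl group, or with a methoxy group on either phenyl ring. They also leave open whether the remaining stereoisomer, the mirror image of compound 3, would behave the same way in this assay, and whether the ring configuration matters for binding to any other receptor.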